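The source may hold more compounds than are shown below. What is called first, only, known or untested is meant among the compounds shown, and "the series" means these compounds.

Measured so far in a functional assay on HepG2 cells (Homo sapiens) for cytotoxicity, with a stated time of 72 h; on this read-out higher numbers stand for an effect only at larger amounts of compound and lower numbers for an effect already at smaller amounts (each entry is a limit, not a number):
- compound 1 `C=C[C@@](C)(/C=C/c1ccc(Nc2ccc(F)c(F)c2)cc1)CCC=C(C)C` with > 52000 nM as its limit
- compound 2 `C=C[C@@](C)(/C=C/c1ccc(-c2ccc(Cl)cc2)cc1)CCC=C(C)C` with > 52000 nM as its limit
- compound 3 `C=C[C@@](C)(/C=C/c1ccc(-c2ccc(Cl)c(Cl)c2)cc1)CCC=C(C)C` with > 52000 nM as its limit

Compound 3 stands at > 52000 nM as a limit, not a number. For the measured compounds named here, the whole set offers the limit of > 52000 nM in this assay, at which 3 of the 3 values shown sit, as its only reading, so compound 3 can be given no rank.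

Compound 4 `C=C[C@@](C)(/C=C/c1ccc(-c2cccc(Br)c2)cc1)CCC=C(C)C` carries 3-bromophenyl in place of 3,4-dichlorophenyl on an aromatic carbon, para to a large group, and 3-bromophenyl in place of 3,4-dichlorophenyl on an aromatic carbon gives the count of that change.

The closest measured change is a step that the two limits leave unreadable from compound 2 to compound 3 for chloro in place of hydrogen on an aromatic carbon. The two exchanges of the whole group on that carbon, a step that the two limits leave unreadable from compound 1 to compound 2 and a step that the two limits leave unreadable from compound 1 to compound 3, are no more informative. None of these steps has a readable size, so none supports a direction.

In this assay no step beyond the scatter is expected, and another limit is the most likely result. That expectation rests on the limit of compound 3 at > 52000 nM and on nothing finer. As an estimate, the expected change is a number no higher from compound 3 to compound 4 (the limit leaves the size open) with no favoured direction. For compound 4 the estimated value is 52000 nM with an expected range of 25000 nM to 100000 nM around it.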

Compound 4, half-maximal effective concentration: > 52000 nM
Compound 4 gave a limit, no number; the forecaster's own chance of this, stated with the estimate: 80%; the middle value lies on the limit itself.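

In this assay compound 4 gives > 52000 nM as a limit and not a number. The steps linking compound 4 with compound 1, compound 2 and compound 3 cannot be read. The series holds a single reading: the limit of > 52000 nM in this assay, at which 4 of the 4 values shown sit. Still open is whether this assay would give a number for any of these compounds, and so whether the exchanges on that aromatic carbon change the read-out at all.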